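Shortening the Side Chain of a Purine Growth Inhibitor

The source may report more compounds than this note shows. Statements on the series, on what has been measured and on what is new or still open speak of the compounds shown alone.

Compounds measured so far:
compound 1, `CCCCn1cnc2c(Nc3ccc(Cl)cc3)nc(N[C@H]3CC[C@H](N)CC3)nc21`: 2700 nM
compound 2, `CCCCn1cnc2c(Nc3ccccc3)nc(N[C@H]3CC[C@H](N)CC3)nc21`: 3200 nM
compound 3, `COc1cc(Nc2nc(N[C@H]3CC[C@H](N)CC3)nc3c2ncn3CCC(C)C)cc(OC)c1`: 2500 nM

In a functional assay on K562 cells (Homo sapiens) for inhibition, read by fluorescence, with a stated time of 72 h (a lower number here means a stronger inhibitor of growth, a higher number a weaker inhibitor of growth), the three numbers stand close together. Compound 3 sits at one end of the span with 2500 nM, and its gaps to compound 1 and to compound 2 both lie within the scatter, so none of the three can be called stronger than another.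

Compound 4, `CCCCn1cnc2c(Nc3cc(OC)cc(OC)c3)nc(N[C@H]3CC[C@H](N)CC3)nc21`, differs from compound 3 in one place: hydrogen in place of methyl on a saturated chain carbon bound to two saturated chain carbons. Read one bond further out, the isopentyl side chain becomes butyl.

For the measured compounds named here, the only measured step, a 1.2-fold higher number from compound 1 to compound 2 (0.07 log units; within the scatter), concerns hydrogen in place of chloro on an aromatic carbon and does not touch the side chain. Going by the values given here, no measured step therefore bears on this change. Compounds 1 and 2 do carry the butyl chain, and their values sit within the scatter of compound 3, though they differ in the aromatic group as well.

The step expected is a 1.0-fold higher number from compound 3 to compound 4 (0.02 log units; within the scatter), none beyond the scatter. Compound 4 is expected to give 2600 nM, between 1100 nM and 6500 nM.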

Compound 4, concentration for 50% growth inhibition: 2400 nM
Compound 4: middle estimate off by 1.1-fold (0.03 log units), on the high side, and the stated range covers the measured number.
By their numbers in this assay, from the lowest: compounds 4, 3, 1 and 2 (each within the scatter of the next).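

Cutting the isopentyl side chain back to butyl is the first measured step at this position in this assay (a 1.0-fold lower number from compound 3 to compound 4 (0.02 log units; within the scatter)), and it stays within the scatter, so this methyl can go without a measurable difference in this assay. For the compounds shown here, with the butyl chain held fixed, the aromatic group on the nitrogen can also be compared for the first time with 3,5-dimethoxyphenyl in the set: against phenyl the step is (a 1.3-fold lower number from compound 2 to compound 4 (0.12 log units; within the scatter)), and against 4-chlorophenyl it is (a 1.1-fold lower number from compound 1 to compound 4 (0.05 log units; within the scatter)), both also within the scatter. Nothing available explains why these numbers stay so close together.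

These compounds span only isopentyl and butyl on that nitrogen of the core. A much shorter chain such as ethyl, or a chain ending in an amine or a carboxylic acid, remains an open question.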